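This account rests on a few compounds, and the source may have more. Where it says the series, first, only, none or still open, it means among the compounds named here.

Among the measured compounds shown here, in an assay for inhibition of steroid 17-alpha-hydroxylase/17,20 lyase (Homo sapiens), using NADPH, tested at 0.2 uM (a lower number here means a weaker effect, a higher number a stronger effect of the compound at the concentration tested), compound 1 `CCC(c1ccc(-c2cscc2C)cc1)n1ccnc1` gives 27%, the highest of the three numbers measured so far. Compound 2 `Cc1cscc1-c1ccc(Cn2ccnc2)cc1` gives 0%, and compound 3 `c1ccc(-c2ccc(Cn3ccnc3)cn2)cc1` gives 0%. For the measured compounds named here, the one step measured between structures that differ in a single place, a number 27 percentage points lower from compound 1 to compound 2 (beyond the scatter), came with the loss of an ethyl group from a saturated chain carbon; compound 3 shares no single change with the others, so of compounds 2 and 3 only the two values themselves can be read. Compound 4 `CCC(c1ccc(-c2ccsc2)cc1)n1ccnc1` differs from compound 1 in one place: hydrogen in place of methyl on an aromatic carbon. Going by the values given here, no measured step touches a change of this kind, since the only step known removes a different group from a different place and offers no direct guide. The change leaves a methyl group and nothing more. The step expected is a number 7 percentage points lower from compound 1 to compound 4 (within the scatter), which would not reach beyond the usual scatter. Compound 4 is therefore expected to give about 20% in this assay, with a likely range from 5% to 38%.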

Compound 4, a percentage reported as inhibition, at one concentration (the size of the read-out at that concentration, not a potency): 28%
For compound 4 the middle estimate is 8 percentage points below the measured one; the range from low to high includes it.
By their numbers in this assay, from the lowest: compounds 2 and 3 (each within the scatter of the next); then compounds 1 and 4 (each within the scatter of the next).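

Going from 4-methylthiophen-3-yl to thiophen-3-yl in this assay gives a number 1 percentage points higher from compound 1 to compound 4 (within the scatter), so at this ring carbon the methyl group can be replaced by hydrogen without a change that stands clear of the usual scatter. Among the compounds shown here, the only earlier step lay elsewhere, at the saturated chain carbon, where losing ethyl gave a number 27 percentage points lower from compound 1 to compound 2 (beyond the scatter), and it said nothing about this position on the ring. No measured evidence accounts for this result.

Still open, on these data alone, is whether a methoxy group, an amine or a longer chain at this same ring carbon would leave the number where it stands. Also open, as far as these compounds go, is whether the thiophen-3-yl group would give the same reading with hydrogen in place of ethyl on the chain carbon.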